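Swapping hydroxy for an amino group on the ring

The source may report more compounds than this note shows. Statements on the series, on what has been measured and on what is new or still open speak of the compounds shown alone.

compound 1 `CCC(=O)N(c1ccc(Cl)c(Cl)c1)C1CCCC1O` gives 9 mg/kg
compound 2 `CCC(=O)N(c1ccc(Cl)c(C)c1)C1CCCC1N(C)C` gives 2 mg/kg
compound 3 `CCC(=O)N(c1ccc(C(=O)OC)cc1)C1CCCC1N(C)C` gives > 50 mg/kg

In a functional assay on the whole organism for antagonist activity, with Mus musculus as the target (a higher number here means that more compound is needed for the effect, a lower number that less compound is needed), compound 1 stands highest of the two actual numbers at 9 mg/kg on the dose scale. It needs more compound than compound 2, which gives 2 mg/kg in a gap beyond the usual scatter. Compound 3 gives > 50 mg/kg as its reading, and that is a limit of the assay.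

Compound 4 `C=CCN(C)C1CCCC1N(C(=O)CC)c1ccc(Cl)c(Cl)c1` has not yet been measured. It keeps the core of compound 1 with one change: allyl(methyl)amino in place of hydroxy on a saturated ring carbon in words, allyl(methyl)amino in place of hydroxy on a saturated ring carbon.

Going by the values given here, no measured pair isolates this change. The expectation rests on compound 2, which gives 2 mg/kg with a dimethylamino group on a saturated ring carbon, although it also differs from compound 1 elsewhere. Compound 3 carries the same dimethylamino group and goes against this pattern, so the expectation stays loose. In this assay the expected change is a move to a lower dose, an estimated 3.0-fold lower number from compound 1 to compound 4 (0.48 log units; beyond the scatter) that would lie beyond the scatter. For compound 4 the estimate is 3 mg/kg as the middle value, with 0.7 mg/kg to 15 mg/kg as the expected range.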

Compound 4, dose for half-maximal effect: 0.2 mg/kg
Beside the measured number, compound 4's estimate is 15-fold (1.18 log units) above it; the measured number lies below the stated range.
By their numbers in this assay, from the lowest: compound 4; then compound 2; then compound 1. At a limit, above all of these: compound 3.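

In this assay, replacing hydroxy with allyl(methyl)amino on a saturated ring carbon gives a 45-fold lower number from compound 1 to compound 4 (1.65 log units; beyond the scatter). This is the first pair shown that differs in one place only, so it isolates this position, which the earlier compounds could not do because each of them also differed from compound 1 elsewhere. With the rest of compound 1 held fixed, a change at this one position alone shifts the dose by a large step, and since the entering group has no hydrogen-bond donors, a donor at this position is not needed for compound 4 to work at a low dose in this assay.

The compounds shown leave open whether the allyl group itself matters or whether the amine nitrogen alone accounts for the step, a question that a primary amine, or a propyl chain in place of allyl, at this position would help to separate. Nothing measured here explains why this single change has so large an effect.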